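Phenyl in place of propyl on the ring nitrogen

The compounds below may be only part of what the source reports. "The series", "measured", "known", "first", "only" and "open" are said of these compounds alone.

Compound 1 `CCCn1c(/N=C/c2ccc(F)cc2)c(C#N)sc1=S` gives 102 nM in an assay on HEK293 cells for displacement of a labelled ligand from adenosine receptor A1 (Homo sapiens), read by scintillation counting, with a stated time of 60 min; on this read-out lower numbers stand for stronger inhibition and higher numbers for weaker inhibition.
Compound 2 `CCCn1c(/N=C/c2ccc(Cl)cc2)c(C#N)sc1=S` gives 2.32 nM in this assay.

Compound 2 holds the lowest of the two numbers shown; its only neighbour is compound 1, and the step of a 44-fold lower number from compound 1 to compound 2 (1.64 log units; beyond the scatter) separates the two. Compound 3 `N#Cc1sc(=S)n(-c2ccccc2)c1/N=C/c1ccc(Cl)cc1` keeps the chloro-bearing aryl group of compound 2 and differs from it in one place: phenyl in place of propyl on an aromatic nitrogen. Within the data shown here, no measured step touches this position; the single step recorded, from compound 1 to compound 2, changes a halogen on an aromatic carbon and says nothing about what the group on the ring nitrogen does. Among the measured compounds shown here, with no comparable step to lean on, the expected change from compound 2 to compound 3 in this assay is a 3.4-fold higher number from compound 2 to compound 3 (0.54 log units; beyond the scatter), a step of uncertain direction. Compound 3 is therefore estimated at 8 nM, within a wide range from 1 nM to 60 nM.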

Compound 3, inhibition constant: 413 nM
Compound 3: the middle estimate sits 52-fold (1.71 log units) below what was measured; measured number above the stated range.
By their numbers in this assay, from the lowest: compound 2; then compound 1; then compound 3.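

The group on the ring nitrogen proves to be a strong determinant of the result in this assay: phenyl in place of propyl brings a 180-fold higher number from compound 2 to compound 3 (2.25 log units; beyond the scatter), a large step at a position the halogen change had not touched. So the low number of compound 2 depends on more than its chloro substituent, and it does not survive this single change on the aromatic nitrogen. Nothing available gives a measured reason for the step.

On these data alone, it remains open how a longer chain such as butyl, a cyclohexyl ring or a benzyl group on that nitrogen would read in this assay, and so whether the step belongs to phenyl in particular. Also open, as far as these compounds go, is whether the same change would give a step of similar size with fluoro in place of chloro on the aromatic carbon.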